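Replacing the side chain of compound 3 in compound 4

This account rests on a few compounds, and the source may have more. Where it says the series, first, only, none or still open, it means among the compounds named here.

Measured in an ADME assay on microsomes from liver (Homo sapiens) for metabolic stability, read by LC-MS, tested at 1 uM; a higher number here means faster removal of the compound, a lower number slower removal:
Compound 1 `NC(=O)C1CCN(Cc2ccc([C@H]3CC[C@]4(CC3)OOC3(O4)C4CC5CC(C4)CC3C5)cc2)CC1`: 10 mL.min-1.g-1
Compound 2 `c1cc([C@H]2CC[C@]3(CC2)OOC2(O3)C3CC4CC(C3)CC2C4)ccc1OCCOC1CCNCC1`: < 7 mL.min-1.g-1, a limit of the assay
Compound 3 `OC1(COc2ccc([C@H]3CC[C@]4(CC3)OOC3(O4)C4CC5CC(C4)CC3C5)cc2)CCNCC1`: 16 mL.min-1.g-1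

Compound 3 stands within the scatter of compound 1, with a 1.6-fold higher number from compound 1 to compound 3 (0.20 log units; within the scatter). Set against the limit of compound 2, it stands beyond the scatter, with an at least 2.2-fold higher number from compound 2 to compound 3 (0.35 log units; beyond the scatter). Compound 4 `c1cc([C@H]2CC[C@]3(CC2)OOC2(O3)C3CC4CC(C3)CC2C4)ccc1OC1CCNCC1` carries piperidin-4-yl in place of (4-hydroxypiperidin-4-yl)methyl on an oxygen on an aromatic ring. Among the measured compounds shown here, both steps bear on this change, and the one from compound 2 alters the side chain on that same oxygen. In this assay, a modest fall that stays within the scatter is therefore expected, with an estimated 1.5-fold lower number from compound 3 to compound 4 (0.16 log units; within the scatter). The estimate for compound 4 is 11 mL.min-1.g-1, with an expected range of 6 mL.min-1.g-1 to 20 mL.min-1.g-1.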

Compound 4, intrinsic clearance in microsomes: 15 mL.min-1.g-1
Beside the measured number, compound 4's estimate is 1.4-fold (0.13 log units) below it, within the range that was stated.
By their numbers in this assay, from the lowest: compounds 1, 4 and 3 (each within the scatter of the next). At a limit, below all of these: compound 2.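

In this assay piperidin-4-yl on the oxygen on the aromatic ring gives a number within the scatter of (4-hydroxypiperidin-4-yl)methyl (a 1.1-fold lower number from compound 3 to compound 4 (0.03 log units; within the scatter)). The same holds against the (4-carbamoylpiperidin-1-yl)methyl side chain (a 1.5-fold higher number from compound 1 to compound 4 (0.18 log units; within the scatter)). Only the longer 2-((piperidin-4-yl)oxy)ethyl side chain stands apart (an at least 2.1-fold higher number from compound 2 to compound 4 (0.33 log units; beyond the scatter)), and that step rests on a limit of the assay: the limit of < 7 mL.min-1.g-1 in this assay, at which 1 of the 4 values shown sits.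

Whether the extra length of that chain alone accounts for this gap stays open. So does whether a tertiary amine or a carboxylic acid in place of the piperidin-4-yl would move the number.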